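Swapping 4-bromophenyl for 3-chlorophenyl at the assay limit

The compounds below may be only part of what the source reports. "The series", "measured", "known", "first", "only" and "open" are said of these compounds alone.

In an ADME assay on L132 cells (Homo sapiens) for cytotoxicity, read by MTT assay, with a stated time of 48 h (a lower number here means a stronger inhibitor, a higher number a weaker inhibitor), compound 1 `COc1ccccc1-n1cc(COC(=O)/C(C)=C/CC/C(C)=C/CC/C(C)=C/CC[C@@H]2[C@@]3(C)CCC(=O)C(C)(C)[C@H]3CC[C@@]2(C)O)nn1` gives > 150000 nM as its reading, which is a limit of the assay and not a number. Compound 2 `C/C(=C\CC/C(C)=C/CC[C@@H]1[C@@]2(C)CCC(=O)C(C)(C)[C@H]2CC[C@@]1(C)O)CC/C=C(\C)C(=O)OCc1cn(-c2ccc(Br)cc2)nn1` gives > 150000 nM as its reading, again only a limit. Among the measured compounds shown here, compound 2 therefore has no numeric place, and the one other compound shares the limit of > 150000 nM in this assay, at which 2 of the 2 values shown sit, with it.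

Compound 3 `C/C(=C\CC/C(C)=C/CC[C@@H]1[C@@]2(C)CCC(=O)C(C)(C)[C@H]2CC[C@@]1(C)O)CC/C=C(\C)C(=O)OCc1cn(-c2cccc(Cl)c2)nn1` differs from compound 2 by a single change 3-chlorophenyl in place of 4-bromophenyl on an aromatic nitrogen that puts 3-chlorophenyl in place of 4-bromophenyl on an aromatic nitrogen. For the measured compounds named here, the only measured step bearing on this is a step that the two limits leave unreadable from compound 1 to compound 2 with 4-bromophenyl in place of 2-methoxyphenyl on an aromatic nitrogen, and its size cannot be read. It offers no size or direction to carry over, so no shift beyond the scatter is expected in this assay for this swap. The expectation rests on compound 2 and its limit of > 150000 nM alone. The estimated step of a number no higher from compound 2 to compound 3 (the limit leaves the size open) is expected to stay within the scatter. Compound 3 is estimated at 150000 nM with an expected range from 80000 nM to 300000 nM and will probably be reported as a limit again.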

Compound 3, half-maximal inhibitory concentration: 94200 nM
For compound 3 the middle estimate is 1.6-fold (0.20 log units) above the measured one; the measured number falls inside the stated range.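

Among the compounds shown here, compound 3 is the only one of the three with a numeric reading in this assay, so the 3-chlorophenyl group gives this position on the aromatic nitrogen its one measured number so far. Against the earlier compounds the result reads as an at least 1.5-fold lower number from compound 2 to compound 3 (0.20 log units; that floor lies within the scatter) and as an at least 1.5-fold lower number from compound 1 to compound 3 (0.20 log units; that floor lies within the scatter); both are floors set by limits, so the true sizes stay open, and the step between compound 1 and compound 2 cannot be read. The two other aryl groups, 2-methoxyphenyl and 4-bromophenyl, share one limit and are not separated from each other, while the 3-chlorophenyl group stands apart from that shared reading only as far as those floors allow: the limit of > 150000 nM in this assay, at which 2 of the 3 values shown sit.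

The compounds shown leave open whether the reading follows the chlorine or its place on the phenyl ring, as 3-chlorophenyl differs from 4-bromophenyl in both. Going by these compounds, how 4-chlorophenyl, 3-bromophenyl, or a phenyl group carrying an amine or a carboxylic acid would read in this assay also stays open.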